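A few compounds are considered here, and "the series" means these few. Any claim that something is new, unique, unknown or untested is made for them only; others in the source may bear on it.

Compound 1 `COc1ccc(C(=O)/C=C/c2cc(-c3cc(OC)c(OC)c(OC)c3)n[nH]2)cc1OC` and compound 2 `COc1ccc(C(=O)/C=C/c2cc(-c3cc(OC)c(OC)c(OC)c3)n[nH]2)cc1` share one core and differ only on the left-hand aromatic ring. In a functional assay on BT-549 cells (Homo sapiens) for cytotoxicity, read by sulforhodamine B assay, with a stated time of 48 h, tested at 0.01 uM (on this read-out lower numbers stand for a stronger effect and higher numbers for a weaker effect at the one concentration tested), compound 1 gives 95%, and compound 2 gives 97%. On these two numbers compound 1 stands lowest, with compound 2 as its nearest neighbour; the step of a number 2 percentage points higher from compound 1 to compound 2 (within the scatter) is within the scatter, so the two read-outs cannot be told apart.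

Compound 3 `COc1cc(C(=O)/C=C/c2cc(-c3cc(OC)c(OC)c(OC)c3)n[nH]2)cc(OC)c1OC` has not yet been measured in this assay. It differs from compound 1 by a single change: methoxy in place of hydrogen on an aromatic carbon. Within the data shown here, the only measured step that bears on this change is the one from compound 1 to compound 2, which removed a methoxy from the same ring and moved the read-out by an amount within the scatter. Adding a further methoxy to that ring is the opposite kind of change, and on this evidence no step beyond the scatter is expected in this assay for compound 3.

The read-out for compound 3 is therefore estimated at 95%, with a range from 84% to 104%, an expected step of no change at the digits printed from compound 1 to compound 3 (within the scatter) from compound 1.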

Compound 3, a percentage reported as activity, at one concentration (the size of the read-out at that concentration, not a potency): 102%
Estimate against measurement, compound 3: 7 percentage points below, within the range that was stated.
By their numbers in this assay, from the lowest: compounds 1, 2 and 3 (each within the scatter of the next).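

At this position, an aromatic carbon ortho to a methoxy group and meta to a large group, methoxy in place of hydrogen gives a number 7 percentage points higher from compound 1 to compound 3 (within the scatter) in this assay. The earlier pair showed only what taking a methoxy off the left-hand ring does, whereas this pair shows the opposite kind of change on that ring, and this step too stays within the usual scatter of the measurement, so adding this group at this place has no effect that can be told apart at the one concentration tested. No accompanying measurement speaks to what lies behind this number.

What the compounds shown leave open is whether a group other than methoxy on this same carbon, such as a hydroxyl, an amine or a carboxylic acid, would give a read-out beyond the scatter in this assay. Also open, on these data alone, is how compound 1 and compound 3 would compare at other concentrations, since a single-concentration read-out is not a potency and cannot show whether the added methoxy matters once the compounds act more strongly on the cells.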